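This account rests on a few compounds, and the source may have more. Where it says the series, first, only, none or still open, it means among the compounds named here.

Measured so far, in a functional assay for inhibition of sodium/hydrogen exchanger (Oryctolagus cuniculus); on this read-out higher numbers stand for weaker inhibition and lower numbers for stronger inhibition:

Compound 1, `CCCCCc1cc(C)c(C(=O)N=C(N)N)cc1S(C)(=O)=O`, gives 27 nM.
Compound 2, `CSc1cc(C)c(C(=O)N=C(N)N)cc1S(C)(=O)=O`, gives 6 nM.
Compound 3, `Cc1cc(N2CCCC(O)C2)c(S(C)(=O)=O)cc1C(=O)N=C(N)N`, gives 30 nM.

All three compounds share the same core and differ only in the group carried on one aromatic carbon. Among these three numbers, compound 3 has the highest. It sits close to compound 1, since the step of a 1.1-fold higher number from compound 1 to compound 3 (0.05 log units; within the scatter) stays within the scatter, whereas the step of a 5.0-fold higher number from compound 2 to compound 3 (0.70 log units; beyond the scatter) is a clear gap; the same contrast appears in the step of a 4.5-fold lower number from compound 1 to compound 2 (0.65 log units; beyond the scatter).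

Compound 4, `Cc1cc(N)c(S(C)(=O)=O)cc1C(=O)N=C(N)N`, has not yet been measured. It carries the change (amino in place of 3-hydroxypiperidin-1-yl on an aromatic carbon). The step from compound 3 to compound 4 therefore again replaces the group on that aromatic carbon, and the measured steps show that such replacements have shifted the read-out by a modest amount at most, in either direction. A small group, methylsulfanyl in compound 2, gave the lowest number, which is the only hint that a small group might favour a lower number here.

On this basis, the step of a 2.0-fold lower number from compound 3 to compound 4 (0.30 log units; within the scatter) is expected to be modest, with a slight lean toward a lower number. Compound 4 is thus estimated at 15 nM, with a range from 4 nM to 60 nM.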

Compound 4, half-maximal inhibitory concentration: 16 nM
The estimate for compound 4 lay 1.1-fold (0.03 log units) below the measured number; the measured number falls inside the stated range.
By their numbers in this assay, from the lowest: compound 2; then compounds 4, 1 and 3 (each within the scatter of the next).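

Cutting the 3-hydroxypiperidin-1-yl group down to amino, a single heavy atom with no ring, leaves the number in this assay within the scatter (a 1.9-fold lower number from compound 3 to compound 4 (0.27 log units; within the scatter)), and the same holds against the pentyl group (a 1.7-fold lower number from compound 1 to compound 4 (0.23 log units; within the scatter)). This position therefore accepts three very different groups, a ring, an open chain and amino, with no separation among compounds 1, 3 and 4. A small group alone also does not reproduce the low number of compound 2, since amino stays apart from methylsulfanyl by a modest step beyond the scatter (a 2.7-fold higher number from compound 2 to compound 4 (0.43 log units; beyond the scatter)), and no measurement at hand explains that difference.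

The compounds shown do not tell whether the low number of compound 2 belongs to the sulfur of methylsulfanyl or to some other feature of that group, a question that methoxy or ethylsulfanyl on the same aromatic carbon could help to settle. They also leave open whether methylamino or dimethylamino would stay with amino or move toward compound 2.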